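Compound 2 to compound 4: a longer side chain

This account rests on a few compounds, and the source may have more. Where it says the series, first, only, none or still open, it means among the compounds named here.

Compound 1 `CC1(C)[C@@H](Cn2nnc3c(N)nc(N)nc32)CC[C@@]1(C)CO`: > 200000 nM, a limit of the assay and not a number
Compound 2 `C=Cc1cn([C@H]2C[C@H](O)[C@@H](CO)O2)c(=O)[nH]c1=O`: 14200 nM
Compound 3 `Nc1nc2c(nc(I)n2COCCO)c(=O)[nH]1`: 111000 nM

All three compounds were tested in an ADME assay on L1210/0 cells (Mus musculus) for cytotoxicity, with a stated time of 48 h; a higher number here means a weaker inhibitor, a lower number a stronger inhibitor. Of the two exact numbers, compound 2 has the lower one at 14200 nM. Among the compounds with values here, the only other exact number belongs to compound 3 at 111000 nM, and the gap between the two lies beyond the usual scatter.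

Compound 4 `O=c1[nH]c(=O)n([C@H]2C[C@H](O)[C@@H](CO)O2)cc1C#CCO` has not yet been measured. It differs from compound 2 in one place, with 3-hydroxyprop-1-yn-1-yl in place of vinyl on an aromatic carbon.

Within the data shown here, no measured pair of compounds shows what a change like this does, so any forecast is uncertain. Since compound 2 already has the lowest number at 14200 nM, a rise looks more likely than a fall. That would mean a weaker inhibitor, with a moderate step beyond the scatter. The estimated change is a 3.9-fold higher number from compound 2 to compound 4 (0.59 log units; beyond the scatter). For compound 4, the estimated value is 55000 nM, with an expected range of 12000 nM to 200000 nM.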

Compound 4, half-maximal inhibitory concentration: > 200000 nM
Compound 4 was reported as a limit; the forecaster's own chance of this, stated with the estimate: 30%; middle value at least 3.6-fold (0.56 log units) away from the limit.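

Within the data shown here, this is the first step that changes one place only, and it shows that the group on this aromatic carbon, two atoms from the ring nitrogen, matters in this assay: 3-hydroxyprop-1-yn-1-yl in place of vinyl gives an at least 14-fold higher number from compound 2 to compound 4 (1.14 log units; beyond the scatter). For this pair, then, the shared core does not carry the cell effect on its own, and vinyl is tolerated far better here than the longer chain. The size of the step is only a lower bound and not a measured gap, because compound 4 sits at a limit of the assay and not at a number: the limit of > 200000 nM in this assay, at which 2 of the 4 values shown sit.

Which part of the change counts stays open, since the new group differs from vinyl at once in its length, in its triple bond and in its hydroxy end, and this one pair cannot separate these. A prop-1-yn-1-yl group, with the triple bond but no hydroxy end, or a 3-hydroxypropyl chain, with the hydroxy end but no triple bond, would pull these features apart.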